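Hydroxy to Hydrogen: Compound 3 to Compound 4

The source may report more compounds than this note shows. Statements on the series, on what has been measured and on what is new or still open speak of the compounds shown alone.

Compound 1, `O=C(Nc1ccc(Sc2nc3ccccc3s2)c(Cl)c1)c1cc(Br)cc(Br)c1`, in an assay on isolated protein for inhibition of thiosulfate sulfurtransferase (Homo sapiens), with a stated time of 60 min, in the absence of a further agent (a lower number here means a stronger inhibitor, a higher number a weaker inhibitor), gives > 100000 nM, a limit of the assay. Compound 2, `COc1ccc(Br)cc1C(=O)Nc1ccc(Sc2nc3ccccc3s2)cc1`, gives in this assay > 100000 nM, also a limit. Compound 3, `O=C(Nc1ccc(Sc2nc3ccccc3s2)c(Cl)c1)c1cccc(Br)c1O`, gives in this assay > 100000 nM, again a limit.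

Compound 3 therefore stands only at a limit, as do both other measured compounds, so that (the limit of > 100000 nM in this assay, at which 3 of the 3 values shown sit). Going by the values given here, the one measured step, a step that the two limits leave unreadable from compound 1 to compound 3, is unreadable because of the limit of > 100000 nM in this assay, at which 3 of the 3 values shown sit. Compound 4, `O=C(Nc1ccc(Sc2nc3ccccc3s2)c(Cl)c1)c1cccc(Br)c1`, differs from compound 3 by hydrogen in place of hydroxy on an aromatic carbon. No measured step bears on this change, and nothing among the shown values points away from the limit. The expected step in this assay is therefore a step that the limit leaves unreadable from compound 3 to compound 4, none beyond the scatter. Compound 4 is expected to give 150000 nM in this assay, between 60000 nM and 400000 nM.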

Compound 4, half-maximal inhibitory concentration: > 100000 nM
Compound 4: only a limit was reported; the forecaster's own chance of this, stated with the estimate: 85%; the middle value does not contradict the limit.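

In this assay, going by these compounds alone, no step from compound 1 or compound 3 to compound 4 can be read, since all of these values are limits: the limit of > 100000 nM in this assay, at which 4 of the 4 values shown sit.

The compounds shown leave open which change to the shared core would give a value that is not a limit.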